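The source may report more compounds than this note shows. Statements on the series, on what has been measured and on what is new or still open speak of the compounds shown alone.

Three compounds share one core and differ only in the group carried on the amine nitrogen. Compound 1 `COc1cc(Oc2cccc(Nc3ccccc3)c2)cc(OC)c1CNCc1ccc(Br)cc1` gives 5410 nM in a functional assay on HCT-15 cells (Homo sapiens) for inhibition, read by MTT assay, with a stated time of 72 h; on this read-out higher numbers stand for weaker inhibition and lower numbers for stronger inhibition. Compound 2 `COc1cc(Oc2cccc(Nc3ccccc3)c2)cc(OC)c1CNC1CC1` gives 6140 nM in this assay. Compound 3 `COc1cc(Oc2cccc(Nc3ccccc3)c2)cc(OC)c1CNCCNC(C)=O` gives 5090 nM in this assay. None of these numbers is separated from another: there is a 1.1-fold higher number from compound 1 to compound 2 (0.05 log units; within the scatter), a 1.1-fold lower number from compound 1 to compound 3 (0.03 log units; within the scatter) and a 1.2-fold lower number from compound 2 to compound 3 (0.08 log units; within the scatter), so compound 3 sits within the scatter of both other compounds, and no one of the three can be called more or less potent than another.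

Compound 4 `COc1ccc(CNCc2c(OC)cc(Oc3cccc(Nc4ccccc4)c3)cc2OC)cc1` is the next step from compound 3: 4-methoxyphenyl in place of acetamidomethyl on a saturated chain carbon bound to an amine nitrogen. Among the compounds with values here, the step that bears most on it is the one from compound 1 to compound 3, where an aromatic ring on that carbon gave way to acetamidomethyl and the number moved by a 1.1-fold lower number from compound 1 to compound 3 (0.03 log units; within the scatter); the step from compound 1 to compound 2 also swapped that region and moved by a 1.1-fold higher number from compound 1 to compound 2 (0.05 log units; within the scatter). Putting an aromatic ring back on that carbon is therefore expected to leave the number where it is, with a step of a 1.0-fold higher number from compound 3 to compound 4 (0.02 log units; within the scatter) that stays within the scatter. Compound 4 is estimated at 5300 nM in this assay, with a range from 2700 nM to 10600 nM.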

Compound 4, half-maximal inhibitory concentration: 2650 nM
The estimate for compound 4 lay 2.0-fold (0.30 log units) above the measured number; the whole stated range lies above it.
By their numbers in this assay, from the lowest: compounds 4, 3, 1 and 2 (each within the scatter of the next, the first and the last beyond it).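

Within the data shown here, until this result, no change on the amine nitrogen had separated one compound from another, but two steps now do so, if only modestly, in this assay. Methoxy in place of bromo on an aromatic carbon gives a separated step (a 2.0-fold lower number from compound 1 to compound 4 (0.31 log units; beyond the scatter)), and 4-methoxybenzyl in place of cyclopropyl on an amine nitrogen gives another (a 2.3-fold lower number from compound 2 to compound 4 (0.36 log units; beyond the scatter)), so the number can respond to this region, even to a change of one group on an otherwise unchanged aromatic ring. The change from acetamidomethyl to 4-methoxyphenyl stays within the scatter (a 1.9-fold lower number from compound 3 to compound 4 (0.28 log units; within the scatter)), so compound 4 cannot be ranked ahead of compound 3, and the presence of an aromatic ring alone does not separate compounds, as compound 1 also carries one. No evidence is given on why these numbers differ.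

The compounds shown leave open whether the methoxy group itself matters or whether the bromo group is the less favourable of the two, which a plain benzyl group on the amine nitrogen could help to settle. They also leave open how a 4-hydroxybenzyl or 4-aminobenzyl group would compare with 4-methoxybenzyl at this place.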